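A few compounds are considered here, and "the series" means these few. Any claim that something is new, unique, unknown or untested is made for them only; others in the source may bear on it.

Measured compounds:
- Compound 1, `CCOC(=O)N1CCC(NS(=O)(=O)c2ccc(C(=O)NC3CCCCC3)c3ccccc23)CC1`: in an assay on L1.2 cells for binding affinity to C-C chemokine receptor type 8 (Homo sapiens) (on this read-out higher numbers stand for weaker inhibition and lower numbers for stronger inhibition), compound 1 gives 9.5 nM.
- Compound 2, `CCOC(=O)N1CCC(NS(=O)(=O)c2ccc(NCCCc3ccccc3)c3ccccc23)CC1`: compound 2 gives 32.1 nM.
- Compound 3, `CCOC(=O)N1CCC(NS(=O)(=O)c2ccc(O)c3ccccc23)CC1`: compound 3 gives > 5000 nM, which is a limit of the assay and not a number.

Compound 3 therefore stands at the weak end of the three, its result sitting at the limit of > 5000 nM in this assay, at which 1 of the 3 values shown sits. The steps that lead to it are large: an at least 520-fold higher number from compound 1 to compound 3 (2.72 log units; beyond the scatter) and an at least 150-fold higher number from compound 2 to compound 3 (2.19 log units; beyond the scatter), while between the two stronger compounds there is only a modest gap, a 3.4-fold higher number from compound 1 to compound 2 (0.53 log units; beyond the scatter). Compound 4, `CCOC(=O)N1CCC(NS(=O)(=O)c2ccc(OC(=O)c3ccccc3)c3ccccc23)CC1`, carries the change (benzoyl in place of hydrogen on an oxygen on an aromatic ring). In both measured steps, trading a larger group for hydroxy at this ring position raised the number greatly; putting a benzoyl group back onto that oxygen is expected to move the number in the opposite direction, an expected step of an at least 16-fold lower number from compound 3 to compound 4 (1.22 log units; beyond the scatter), though how far is uncertain. For compound 4 the expected value in this assay is 300 nM, within a range of 30 nM to 4000 nM.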

Compound 4, inhibition constant: 16.4 nM
Estimate against measurement, compound 4: 18-fold (1.26 log units) above; the measured number lies below the stated range.
By their numbers in this assay, from the lowest: compounds 1, 4 and 2 (each within the scatter of the next, the first and the last beyond it). At a limit, above all of these: compound 3.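

Putting benzoyl on the oxygen of compound 3 brings back strong binding, an at least 300-fold lower number from compound 3 to compound 4 (2.48 log units; beyond the scatter), so a large group can be attached at this position through oxygen, not only through the carbonyl carbon of compound 1 or the nitrogen of compound 2. The size of that step is only a bound, as the result for compound 3 is a limit of the assay and not a number: the limit of > 5000 nM in this assay, at which 1 of the 4 values shown sits. Compound 4 cannot be told apart from either neighbour, with a 2.0-fold lower number from compound 2 to compound 4 (0.29 log units; within the scatter) and a 1.7-fold higher number from compound 1 to compound 4 (0.24 log units; within the scatter), even though these three groups are joined to the aromatic carbon through different atoms.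

From the compounds shown here alone, it remains open whether the benzene ring of benzoyl or its carbonyl matters more, which a small acetyl group or a benzyl group on the same oxygen would help to separate. Going by these compounds, how a basic amine or a carboxylic acid would fare at this position is also open.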